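The compounds below may be only part of what the source reports. "The series", "measured", "known", "first", "only" and "open" are said of these compounds alone.

Measured compounds:
Compound 1, `CC(C)[C@H](C(=O)Nc1nc2cc(Cl)ccc2o1)c1ccc(Cl)cc1`, in a functional assay on CHO cells for agonist activity at Free fatty acid receptor 2 (Homo sapiens), read by cAMP accumulation; a higher number here means a larger maximal response, a lower number a smaller maximal response: compound 1 gives 88%.
Compound 2, `CC(C)(C)[C@H](C(=O)Nc1ncc(C(F)(F)F)s1)c1ccc(Cl)cc1`: compound 2 gives 95% in this assay.
Compound 3, `CCC[C@H](C(=O)Nc1nccs1)c1ccc(Cl)cc1`: compound 3 gives 108% in this assay.

Compound 3 stands highest of the three in this assay; its maximal response lies beyond the scatter above compound 2 and further still above compound 1. Among the measured compounds shown here, all three share the same amide linkage from a branched chain carbon to a heteroaromatic amine, and differ in the branch and in the heteroaromatic part, so no single-change step between measured compounds is available.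

Compound 4, `C=CC[C@H](C(=O)Nc1nccs1)c1ccc(Cl)cc1`, is not yet measured. It differs from compound 3 in one place: vinyl in place of ethyl on a saturated chain carbon, two bonds along the chain from an aromatic carbon and a carbonyl carbon. The change leaves the heteroaromatic part and the amide untouched and keeps the same count of heavy atoms in the branch. For the measured compounds named here, no measured pair shows what such a change does here, so the expectation rests on the closeness of the two structures alone: the step from compound 3 to compound 4 in this assay is expected to be small, a number 6 percentage points lower from compound 3 to compound 4 (within the scatter), and not beyond the scatter in either direction. For compound 4 a maximal response of 102% is estimated, with a range from 86% to 118%.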

Compound 4, largest response reached (reported as efficacy), in percent of the reference or control that the assay uses: 88%
Compound 4: middle estimate off by 14 percentage points, on the high side; the measured number falls inside the stated range.
By their numbers in this assay, from the lowest: compounds 1, 4 and 2 (each within the scatter of the next); then compound 3.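

In this assay, among the compounds shown here, vinyl in place of ethyl on a saturated chain carbon, two bonds along the chain from an aromatic carbon and a carbonyl carbon, gives a number 20 percentage points lower from compound 3 to compound 4 (beyond the scatter) and so provides the first single-change step. The maximal response is therefore sensitive to the end of this branch: the swap leaves the heavy-atom count unchanged and adds only a double bond outside aromatic rings, yet the step lies beyond the scatter. Nothing available gives a reason for this step. The compounds shown leave open how a longer saturated chain such as butyl, or an amine or a hydroxyl at the end of the branch, would compare with propyl and allyl. They also leave open whether the same swap has a similar effect when the heteroaromatic part carries a substituent.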